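Replacing an Ester with an Aminophenyl Group

The compounds below may be only part of what the source reports. "The series", "measured", "known", "first", "only" and "open" are said of these compounds alone.

Measured so far:
- compound 1, `COC(=O)c1ccc(NC2=CC(=O)c3ncncc3C2=O)cc1`, 2200 nM
- compound 2, `COc1ccc(NC2=CC(=O)c3ncncc3C2=O)cc1OC`, 1800 nM
- compound 3, `COc1cc(NC2=CC(=O)c3ncncc3C2=O)cc(OC)c1`, 7700 nM

All three compounds share one core and differ only in the groups carried on the aromatic ring attached through the amine. In a functional assay on MIA PaCa-2 cells (Homo sapiens) for cytotoxicity, read by MTT assay, with a stated time of 72 h (a higher number here means a weaker inhibitor, a lower number a stronger inhibitor), compound 1 gives 2200 nM, the second highest of the three numbers. Compound 2 sits within the usual scatter of compound 1, so nothing separates them; compound 3, with the highest number, stands beyond the scatter from compound 1.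

The next compound, compound 4, `Nc1ccc(-c2ccc(NC3=CC(=O)c4ncncc4C3=O)cc2)cc1`, differs from compound 1 in one place:

4-aminophenyl in place of methoxycarbonyl on an aromatic carbon

Among the measured compounds shown here, no two of the measured compounds differ in a single place, so there is no measured step to lean on. The three measured values all lie within a moderate band, which suggests the group on this ring does not move the number enormously. Compound 4 is therefore expected to show a small step, a 1.5-fold lower number from compound 1 to compound 4 (0.17 log units; within the scatter), leaning toward a lower number but not clearly beyond the scatter. The estimated value for compound 4 in this assay is 1500 nM, with a plausible range from 500 nM to 5000 nM.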

Compound 4, half-maximal inhibitory concentration: 2500 nM
Compound 4: the middle estimate sits 1.7-fold (0.22 log units) below what was measured; measured number inside the range.
By their numbers in this assay, from the lowest: compounds 2, 1 and 4 (each within the scatter of the next); then compound 3.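

Among the compounds shown here, putting 4-aminophenyl in place of methoxycarbonyl, on an aromatic carbon para to a large group, gives the first single-place comparison in this set: in this assay, the step is a 1.1-fold higher number from compound 1 to compound 4 (0.06 log units; within the scatter), which lies within the scatter. The change is far from small on paper, since a group with no ring and no hydrogen-bond donor leaves, while a larger group with a six-membered aromatic ring and a hydrogen-bond donor enters, yet this readout does not separate the two compounds. So, for this one pair, the position takes the larger aminophenyl group with no change that can be told from scatter, and no measurement shown here explains why the two groups read alike.

One exchange cannot show whether other groups on this carbon would behave the same way, such as a lone amine, a carboxylic acid or a longer chain. It also leaves open whether the amine on the added ring matters at all, which a plain phenyl ring on the same carbon would help to test.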